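Urea in Place of Sulfonamide on a Weakly Active Series

The source may hold more compounds than are shown below. What is called first, only, known or untested is meant among the compounds shown, and "the series" means these compounds.

Compound 1, `O=C(Nc1cccc(-c2nc(-c3ccc(NC(=O)c4cccnc4)cc3Cl)no2)c1)c1ccccc1`, in a functional assay on MDA-MB-231 cells (Homo sapiens) for antiproliferative activity, read by MTT assay, with a stated time of 72 h; on this read-out higher numbers stand for weaker inhibition and lower numbers for stronger inhibition: 12800 nM.
Compound 2, `O=C(Nc1ccc(-c2noc(-c3cccc(NS(=O)(=O)c4cccc(Cl)c4)c3)n2)c(Cl)c1)c1cccnc1`, in this assay: > 10000 nM, a limit of the assay.
Compound 3, `COc1cccc(S(=O)(=O)Nc2cccc(-c3nc(-c4ccc(NC(=O)c5cccnc5)cc4Cl)no3)c2)c1`, in this assay: > 10000 nM, a limit of the assay.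

Compound 3 therefore stands at a limit, as does compound 2 (the limit of > 10000 nM in this assay, at which 2 of the 3 values shown sit), and only compound 1 carries a number. The step from compound 1 to compound 3 is a step that the limit leaves unreadable from compound 1 to compound 3, and that from compound 2 to compound 3 is a step that the two limits leave unreadable from compound 2 to compound 3. Compound 4, `O=C(Nc1ccccc1)Nc1cccc(-c2nc(-c3ccc(NC(=O)c4cccnc4)cc3Cl)no2)c1`, differs from compound 3 in one place: phenylcarbamoyl in place of (3-methoxyphenyl)sulfonyl on a nitrogen on an aromatic ring. No readable step bears on this change, so the expectation rests on the weak values throughout the set. Compound 4 is expected to give 12000 nM in this assay, within a range from 4000 nM to 40000 nM. The expected step is a step that the limit leaves unreadable from compound 3 to compound 4.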

Compound 4, half-maximal inhibitory concentration: > 10000 nM
Compound 4: a limit, no number; the forecaster's own chance of this, stated with the estimate: 50%; the middle value does not contradict the limit.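

No step from compound 4 to compound 1, compound 2 or compound 3 can be read, because the comparison rests on a limit: the limit of > 10000 nM in this assay, at which 3 of the 4 values shown sit.

Going by these compounds, whether phenylcarbamoyl, benzoyl or either sulfonyl group on the nitrogen gives stronger inhibition remains open.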